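The compounds below may be only part of what the source reports. "The series", "measured", "known", "first", "only" and "open" are said of these compounds alone.

Compound 1 (`COc1cc(OC)c(/C=C/S(=O)(=O)Nc2ccc(OC)c(F)c2)c(OC)c1`): 200 nM
Compound 2 (`COc1cc(OC)c(/C=C/S(=O)(=O)Nc2ccc(OC)c(NC(C)C(=O)O)c2)c(OC)c1`): 40 nM

Both numbers come from a functional assay on DU-145 cells (Homo sapiens) for cytotoxicity, read by trypan blue exclusion, with a stated time of 96 h; a lower number here means a stronger inhibitor, a higher number a weaker inhibitor. Going by the values given here, compound 2 holds the lower of the two, and compound 1 is its only neighbour on this scale. Compound 3 (`COc1cc(OC)c(/C=C/S(=O)(=O)Nc2ccc(OC)c(NC(C(=O)O)c3ccccc3)c2)c(OC)c1`) has not yet been measured. It differs from compound 2 as follows: phenyl in place of methyl on a saturated chain carbon bound to a carbonyl carbon and a nitrogen on an aromatic ring. In words, this is phenyl in place of methyl on a saturated chain carbon bound to a carbonyl carbon and a nitrogen on an aromatic ring.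

Among the compounds with values here, only one measured step bears on this change, and only indirectly. The modest step of a 5.0-fold lower number from compound 1 to compound 2 (0.70 log units; beyond the scatter) came with (1-carboxyethyl)amino in place of fluoro on an aromatic carbon, and so it installed the chain that is altered here. Within the data shown here, no measured step touches the methyl itself, so the data fix neither the size nor the direction of the change. Starting from compound 2 at 40 nM, a small move toward a higher number is expected in this assay, possibly no larger than the scatter. The expected change is a 1.8-fold higher number from compound 2 to compound 3 (0.24 log units; within the scatter) in this estimate. For compound 3 the estimated value is 70 nM, with an expected range of 20 nM to 250 nM.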

Compound 3, half-maximal inhibitory concentration: 75 nM
Estimate against measurement, compound 3: 1.1-fold (0.03 log units) below; the measured number falls inside the stated range.
By their numbers in this assay, from the lowest: compounds 2 and 3 (each within the scatter of the next); then compound 1.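

In this assay, the saturated chain carbon bound to a carbonyl carbon and a nitrogen on an aromatic ring accepts phenyl in place of methyl with a 1.9-fold higher number from compound 2 to compound 3 (0.27 log units; within the scatter). Going by these compounds alone, a single carbon can thus give way to a six-membered aromatic ring at this place with no change that stands out from the scatter, something the earlier compounds, both lacking any such ring, could not show. The advantage over fluoro also persists with the larger group, at a 2.7-fold lower number from compound 1 to compound 3 (0.43 log units; beyond the scatter), so it is not confined to (1-carboxyethyl)amino, although nothing in the material shown offers a reason for either step.

The compounds shown leave open whether the carboxylic acid is needed at all, as a methyl ester or a primary amide in its place would test, and whether the nitrogen on the aromatic ring matters, as an oxygen there would test. They also leave open how far this place can be extended, for which a benzyl or a cyclohexyl group in place of phenyl would give the next reading.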